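Replacing oxan-3-yl on the sulfonyl sulfur of compound 3

A few compounds are considered here, and "the series" means these few. Any claim that something is new, unique, unknown or untested is made for them only; others in the source may bear on it.

Three compounds have been measured in a physicochemical assay for solubility, in phosphate buffer, with a stated time of 24 h, at pH 7.4, tested at 100 uM (a higher number here means a more soluble compound, a lower number a less soluble compound), with these results:

Compound 1 `O=C(NCc1ccc(S(=O)(=O)c2ccccc2)cc1)N1Cc2ccncc2C1` gives 115000 nM
Compound 2 `O=C(NCc1ccc(S(=O)(=O)c2cccc(C(F)(F)F)c2)cc1)N1Cc2ccncc2C1` gives 10000 nM
Compound 3 `O=C(NCc1ccc(S(=O)(=O)C2CCCOC2)cc1)N1Cc2ccncc2C1` gives 208000 nM

Compound 3 lies within the scatter of compound 1, and both stand well clear of compound 2. The gap on that side is large, with a 21-fold higher number from compound 2 to compound 3 (1.32 log units; beyond the scatter) as the measured step.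

Compound 4 `CC(=O)N1CCC(S(=O)(=O)c2ccc(CNC(=O)N3Cc4ccncc4C3)cc2)CC1` has not yet been measured. In it, 1-acetylpiperidin-4-yl stands in place of oxan-3-yl on a sulfonyl sulfur 1-acetylpiperidin-4-yl in place of oxan-3-yl on a sulfonyl sulfur and the rest of the structure is unchanged. Among the compounds with values here, no measured step covers this exact exchange.

Within the data shown here, the nearest precedent is a 1.8-fold higher number from compound 1 to compound 3 (0.26 log units; within the scatter) on the same sulfur, and it stays within the scatter. Among the measured compounds shown here, the large steps, a 12-fold lower number from compound 1 to compound 2 (1.06 log units; beyond the scatter) and the one from compound 2 already given, both involve compound 2, the only compound here with a trifluoromethyl. Neither compound 3 nor compound 4 carries that group.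

No step beyond the scatter is therefore expected in this assay and the estimated step is a 1.2-fold lower number from compound 3 to compound 4 (0.09 log units; within the scatter) on this evidence.

For compound 4 the estimated value is 170000 nM with an expected range from 70000 nM to 350000 nM in this measurement.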

Compound 4, solubility: 187000 nM
Compound 4: the middle estimate sits 1.1-fold (0.04 log units) below what was measured, within the range that was stated.
By their numbers in this assay, from the lowest: compound 2; then compounds 1, 4 and 3 (each within the scatter of the next).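

In this assay, the sulfonyl sulfur takes 1-acetylpiperidin-4-yl, a group of 9 heavy atoms, in place of oxan-3-yl, a group of 6, and the reading holds, with a 1.1-fold lower number from compound 3 to compound 4 (0.05 log units; within the scatter). The comparison with the phenyl compound also stays inside the usual spread, with a 1.6-fold higher number from compound 1 to compound 4 (0.21 log units; within the scatter), so phenyl, oxan-3-yl and 1-acetylpiperidin-4-yl cannot be told apart at this position, and only the 3-(trifluoromethyl)phenyl compound stands apart, with a 19-fold higher number from compound 2 to compound 4 (1.27 log units; beyond the scatter). Nothing available accounts for this tolerance of the larger group at the sulfur.

Going by these compounds, it remains open how this assay would read if the acetyl on the piperidine nitrogen gave way to a free secondary amine, or if a carboxylic acid were placed on that ring. The compounds shown also leave open whether a longer acyl chain on the same nitrogen would stay level with compound 4, or whether the tolerance seen so far has a limit at this sulfur.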